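The compounds below may be only part of what the source reports. "The series", "measured", "known", "first", "only" and "open" are said of these compounds alone.

Compound 1 `CCc1nc(-c2ccc(OC(F)(F)F)cc2OC)c(CC)nc1NC(CC)CC` and compound 2 `CCc1nc(-c2ccc(OC(F)(F)F)cc2OC)c(OC)nc1NC(CC)CC` share one core, while compound 3 `CCc1nc(NC(CC)CC)c(OC)nc1-c1ccc(Cl)cc1Cl` and compound 4 `CCC(CC)Nc1nc(OC)c(-c2ccc(Cl)cc2Cl)nc1OC` share another; the difference between the two cores is not broken down here. In an in vitro ADME assay on microsomes (Homo sapiens) for metabolic stability (on this read-out lower numbers stand for a shorter-lived compound and higher numbers for a longer-lived compound), compound 1 gives 0.217 h, and compound 2 gives 0.867 h. The change between them is methoxy in place of ethyl on an aromatic carbon, and it brought a 4.0-fold higher number from compound 1 to compound 2 (0.60 log units; beyond the scatter). In this assay compound 3 gives 0.583 h. Compound 4 arises from compound 3 by the same kind of change, (methoxy in place of ethyl on an aromatic carbon); the surroundings differ, as the place is here ortho to a 2,4-dichlorophenyl group and para to a methoxy group, where before it was ortho to a large group and para to an ethyl group. Because of a 4.0-fold higher number from compound 1 to compound 2 (0.60 log units; beyond the scatter) a step in the same direction is expected for compound 4, though the unlike surroundings leave its size less certain. For compound 4 the expected step is a 2.7-fold higher number from compound 3 to compound 4 (0.44 log units; beyond the scatter). Compound 4 is estimated at about 1.6 h, likely between 0.7 h and 3.5 h.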

Compound 4, half-life: 0.267 h
For compound 4 the middle estimate is 6.0-fold (0.78 log units) above the measured one; the whole stated range lies above it.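

In this assay, methoxy in place of ethyl brought a 2.2-fold lower number from compound 3 to compound 4 (0.34 log units; beyond the scatter), which is the opposite direction to the earlier pair. The change therefore does not carry over as a fixed step between these two cores: the same change on two cores in this assay, a 4.0-fold higher number (0.60 log units; beyond the scatter) from compound 1 to compound 2 and a 2.2-fold lower number (0.34 log units; beyond the scatter) from compound 3 to compound 4, 8.7-fold (0.94 log units) apart, beyond the scatter of two such steps. This shows that the outcome of the change depends on its surroundings in these two pairs, but it does not show which difference between them matters or how the change would behave on a third core.

The compounds shown leave open whether other groups at this place, such as a chlorine atom, a cyclopropyl group or a longer chain, would also behave differently on the two cores. Also open, going by these compounds, is whether the 2,4-dichlorophenyl group or the neighbouring substituents on the core set the direction.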